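Swapping the anilino ring on a shared core

A few compounds are considered here, and "the series" means these few. Any claim that something is new, unique, unknown or untested is made for them only; others in the source may bear on it.

Compound 1 `COc1ccccc1Nc1nc(SCc2ccc(C(F)(F)F)cc2)nc2ccccc12`: in a functional assay on MGC-803 cells (Homo sapiens) for cytotoxicity, read by MTT assay, with a stated time of 72 h (on this read-out higher numbers stand for weaker inhibition and lower numbers for stronger inhibition), compound 1 gives > 50000 nM, a limit of the assay.
Compound 2 `CCOc1ccccc1Nc1nc(SCc2ccc(C(F)(F)F)cc2)nc2ccccc12`: compound 2 gives > 50000 nM, also a limit.
Compound 3 `COc1ccc(Nc2nc(SCc3ccc(C(F)(F)F)cc3)nc3ccccc23)cc1`: compound 3 gives 13800 nM.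

Compound 1 thus stands only at a limit, and one further value shown sits at the same limit (the limit of > 50000 nM in this assay, at which 2 of the 3 values shown sit). Compound 4 `Fc1ccc(Nc2nc(SCc3ccc(C(F)(F)F)cc3)nc3ccccc23)cc1Cl` differs from compound 1 by 3-chloro-4-fluorophenyl in place of 2-methoxyphenyl on a nitrogen on an aromatic ring. The step that bears on this change is the earlier swap of the aryl ring on the nitrogen on the aromatic ring, an at least 3.6-fold lower number from compound 1 to compound 3 (0.55 log units; beyond the scatter); the step that the two limits leave unreadable from compound 1 to compound 2 cannot be read. A change at the same place, away from 2-methoxyphenyl, is therefore expected to give a lower number in this assay, though its size is uncertain. Compound 4 is estimated at 15000 nM, within a range of 3000 nM to 60000 nM. For compound 4 the expected step is an at least 3.3-fold lower number from compound 1 to compound 4 (0.52 log units; beyond the scatter).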

Compound 4, half-maximal inhibitory concentration: > 50000 nM
Compound 4: only a limit was reported (the forecaster's own chance of this, stated with the estimate: 30%); middle value at least 3.3-fold (0.52 log units) away from the limit.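

In this assay, compound 4 gives > 50000 nM, a limit of the assay, so leaving 2-methoxyphenyl does not by itself lower the number. The 3-chloro-4-fluorophenyl group gives an at least 3.6-fold higher number from compound 3 to compound 4 (0.55 log units; beyond the scatter), so the lower number of compound 3 does not extend to every other aryl ring on this nitrogen. The steps from compound 1 and from compound 2 to compound 4 cannot be read, and the set now gathers at one limit: the limit of > 50000 nM in this assay, at which 3 of the 4 values shown sit.

Going by these compounds, how far apart the compounds at this limit lie stays open. On these data alone, it is also open whether an unsubstituted phenyl ring or a ring carrying an amine would match compound 3.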